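Swapping the cinnamamide aryl group in a quinazoline series

The source may report more compounds than this note shows. Statements on the series, on what has been measured and on what is new or still open speak of the compounds shown alone.

Measured compounds:
- compound 1, `COc1ccc(/C=C/C(=O)Nc2cc3c(Nc4ccc(F)c(Cl)c4)ncnc3cc2O[C@H]2CCOC2)c(OC)c1`: 26500 nM
- compound 2, `COc1cc(/C=C/C(=O)Nc2cc3c(Nc4ccc(F)c(Cl)c4)ncnc3cc2OC)cc(OC)c1`: "not determined" (no result reported)

Among the measured compounds shown here, compound 1 is the only compound here with a number. In a functional assay on HeLa cells (Homo sapiens) for cytotoxicity, read by MTT assay, with a stated time of 72 h (on this read-out higher numbers stand for weaker inhibition and lower numbers for stronger inhibition), compound 1 gives 26500 nM, a weak effect on this read-out. Compound 2 shares the core but carries a methoxy group where compound 1 carries the tetrahydrofuranyloxy group; for compound 2 the entry in this assay reads "not determined" (no result reported), so it cannot serve as a point of comparison.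

Compound 3, `O=C(/C=C/c1ccc(F)cc1Cl)Nc1cc2c(Nc3ccc(F)c(Cl)c3)ncnc2cc1O[C@H]1CCOC1`, keeps everything of compound 1 except the aryl group at the end of the amide-bearing double bond: 2-chloro-4-fluorophenyl in place of 2,4-dimethoxyphenyl on a double-bonded chain carbon bound to a double-bonded chain carbon. For the measured compounds named here, no pair of measured compounds differing in one place is available, so the size of this change has no precedent within these data. Going by the values given here, with only the single value of compound 1 to lean on, the step is expected to stay close to the scatter, with no clear direction; the expected change is a 1.3-fold lower number from compound 1 to compound 3 (0.12 log units; within the scatter). Compound 3 is therefore estimated to give about 20000 nM in this assay, within a range from 7000 nM to 60000 nM.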

Compound 3, half-maximal inhibitory concentration: 37500 nM
Beside the measured number, compound 3's estimate is 1.9-fold (0.27 log units) below it; measured number inside the range.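

Among the compounds shown here, this is the first readable step at this position, on a double-bonded chain carbon bound to a double-bonded chain carbon: in this assay, putting 2-chloro-4-fluorophenyl in place of 2,4-dimethoxyphenyl gives a 1.4-fold higher number from compound 1 to compound 3 (0.15 log units; within the scatter). The exchange is not a small one on paper, since the group that leaves has 2 hydrogen-bond acceptors and the group that enters has 0, with fluorine and chlorine taking the place of the two methoxy groups, yet the two compounds cannot be ranked on this read-out. Nothing shown explains this result.

Only these two aryl groups can be compared, so one step cannot show whether this position is generally tolerant of change or whether these two groups merely happen to give similar numbers. On these data alone, it also remains open whether a phenyl ring carrying an amine or a carboxylic acid would move the number beyond the scatter from compound 1, and how a methoxy group in place of the tetrahydrofuranyloxy group would read, given that compound 2 has no number.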